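This account rests on a few compounds, and the source may have more. Where it says the series, first, only, none or still open, it means among the compounds named here.

In a functional assay on HL-60 cells (Homo sapiens) for inhibition, read by CCK-8 assay, with a stated time of 48 h (a lower number here means a stronger inhibitor, a higher number a weaker inhibitor), compound 1 `COc1ccc(NC(=O)NCCNS(=O)(=O)c2ccc(-c3ccccc3OCc3ccccc3)s2)cc1` gives > 50000 nM, which is a limit and not a number. Compound 2 `O=[N+]([O-])c1ccc(NC(=S)NCCNS(=O)(=O)c2ccc(-c3ccccc3O[C@H]3CC[C@@H](O)CC3)s2)cc1` gives > 50000 nM, which is also a limit. Compound 3 `O=C(NCCNS(=O)(=O)c1ccc(-c2ccccc2OCc2cccc(O)c2)s1)Nc1cc(C(F)(F)F)cc(C(F)(F)F)c1` is the only one of the three with a measured number, at 4000 nM. Compound 1 thus stands at the limit of > 50000 nM in this assay, at which 2 of the 3 values shown sit.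

Compound 4 `COc1cccc(NC(=O)NCCNS(=O)(=O)c2ccc(-c3ccccc3OCc3ccccc3)s2)c1` has the same atoms as compound 1, joined differently: 3-methoxyphenyl in place of 4-methoxyphenyl on an amide-type nitrogen. The 3-methoxyphenyl takes the place of the 4-methoxyphenyl on an amide-type nitrogen, and the rest of the molecule stays as it is. Among the compounds with values here, no measured pair here shows what such a change does, so the direction of any step is open. Within the data shown here, with only this one group altered, compound 4 is expected to stay close to compound 1, whose > 50000 nM is a limit. The expected outcome, an at least 1.2-fold lower number from compound 1 to compound 4 (0.09 log units; that floor lies within the scatter), is a small step at most, and it may well be reported only as a limit again. Compound 4 is estimated at 40000 nM, with an expected range of 15000 nM to 60000 nM.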

Compound 4, half-maximal inhibitory concentration: 1700 nM
Compound 4: middle estimate off by 24-fold (1.37 log units), on the high side; measured number below the stated range.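

In this assay, putting 3-methoxyphenyl in place of 4-methoxyphenyl on an amide-type nitrogen gives an at least 29-fold lower number from compound 1 to compound 4 (1.46 log units; beyond the scatter) and leaves the atom content unchanged, so at this position the outcome depends strongly on where the methoxy group sits on the ring. Within the data shown here, the earlier compounds offered no pair differing in one place, so this is the first direct reading of this position. The size of the step is only a floor, because compound 1 stands at a limit and not at a number: the limit of > 50000 nM in this assay, at which 2 of the 4 values shown sit.

Going by these compounds, what an amine or a carboxylic acid would do in place of the methoxy group on this ring stays open. On these data alone, it is also open whether the same change would give a step of similar size if the benzyl ether elsewhere in the molecule were altered.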